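Removing a Chloro Group from an Inactive Benzamide

The compounds below may be only part of what the source reports. "The series", "measured", "known", "first", "only" and "open" are said of these compounds alone.

Compound 1 `O=C(Nc1ccc(Cl)c(-c2nnc3c(Cl)cccn23)c1)c1ccc(Cl)cc1`: > 100000 nM
Compound 2 `CS(=O)(=O)c1ccc(C(=O)Nc2ccc(Cl)c(-c3nnc4c(Cl)cccn34)c2)c(Cl)c1`: > 100000 nM

In a functional assay on AN3-CA cells (Homo sapiens) for antiproliferative activity, read by MTT assay, with a stated time of 72 h (a lower number here means a stronger inhibitor, a higher number a weaker inhibitor), compound 1 reports only a limit, > 100000 nM, not a number. Compound 2 also reaches only the limit > 100000 nM in this assay. Compound 1 thus sits at the limit of > 100000 nM in this assay, at which 2 of the 2 values shown sit, with no measured value to rank it against. Compound 3 `O=C(Nc1ccc(Cl)c(-c2nnc3c(Cl)cccn23)c1)c1ccccc1` differs from it by hydrogen in place of chloro on an aromatic carbon. Within the data shown here, no measured pair shows such a step, so the step that the limit leaves unreadable from compound 1 to compound 3 is expected to stay within the scatter, with a limit again the most likely outcome. Compound 3 is estimated at 150000 nM, between 30000 nM and 1000000 nM.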

Compound 3, half-maximal inhibitory concentration: 67600 nM
Compound 3: middle estimate off by 2.2-fold (0.35 log units), on the high side; low and high end bracket the measured number.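

Replacing chloro with hydrogen, 4-chlorophenyl to phenyl, yields a real number: in this assay compound 3 gives 67600 nM. The change produces an at least 1.4-fold lower number from compound 1 to compound 3 (0.17 log units; that floor lies within the scatter). Compound 3 is the only compound here that is not held at a limit: the limit of > 100000 nM in this assay, at which 2 of the 3 values shown sit.

Going by these compounds, how large the step really is stays open, as compound 1 has only a limit. Also open, on these data alone, is whether an amine or a methoxy group at this same position would give a lower number than hydrogen does in compound 3.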